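Cytotoxicity series: benzoyl amide replaced by pyrimidinyl amine

A few compounds are considered here, and "the series" means these few. Any claim that something is new, unique, unknown or untested is made for them only; others in the source may bear on it.

Measured compounds:
compound 1 `C[C@@H](Cn1ccc(-c2ccc(C#N)c(Cl)c2)n1)NC(=O)c1ccccc1` gives > 30000 nM
compound 2 `C[C@@H](Cn1ccc(-c2ccc(C#N)c(Cl)c2)n1)NC(=O)c1cccc(OCC(O)CO)c1` gives > 30000 nM
compound 3 `C[C@@H](Cn1ccc(-c2cc(F)c(C#N)c(Cl)c2)n1)NC(=O)Nc1cc(C(C)(C)C)[nH]n1` gives > 30000 nM

Compound 1 stands only at a limit of an ADME assay on PC-3 cells (Homo sapiens) for cytotoxicity, read by CCK-8 assay, with a stated time of 6 days (a lower number here means a stronger inhibitor, a higher number a weaker inhibitor), not at a number. Compound 2 and compound 3 sit at that same limit, as the limit of > 30000 nM in this assay, at which 3 of the 3 values shown sit, records. For the measured compounds named here, the only single-point change among the measured compounds, a step that the two limits leave unreadable from compound 1 to compound 2, is therefore unreadable in size. Compound 4 `C[C@@H](Cn1ccc(-c2ccc(C#N)c(Cl)c2)n1)Nc1cncnc1` differs from compound 1 by pyrimidin-5-yl in place of benzoyl on an amine nitrogen. Going by the values given here, no measured step bears directly on this change, and the three limits give no direction, so no step beyond the scatter is expected; the likeliest outcome is that compound 4 again reaches the limit. Compound 4 is expected at 50000 nM, range 20000 nM to 200000 nM, which means an expected step that the limit leaves unreadable from compound 1 to compound 4.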

Compound 4, half-maximal inhibitory concentration: > 30000 nM
Compound 4: a limit, no number; the forecaster's own chance of this, stated with the estimate: 85%; the middle value does not contradict the limit.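

Compound 4 stands only at a limit, as compound 1 does, so the step between them cannot be read: the limit of > 30000 nM in this assay, at which 4 of the 4 values shown sit. Still open, on these data alone, is whether any of the four compounds gives a numerical read-out, and so how large the change from benzoyl to pyrimidin-5-yl is.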